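The source may report more compounds than this note shows. Statements on the series, on what has been measured and on what is new or still open speak of the compounds shown alone.

Compound 1 `C=C(Br)C(=O)Nc1ccc(C(=O)/C=C/c2ccccc2)cc1` is the reference point of this small set. In a functional assay on MOLT-4 cells (Homo sapiens) for antiproliferative activity, with a stated time of 48 h (a lower number here means a stronger inhibitor, a higher number a weaker inhibitor), compound 1 gives 500 nM. Compound 2 `C=C(Br)C(=O)Nc1ccc(C(=O)/C=C/c2ccc(N(C)C)cc2)cc1` differs from it by one change, (dimethylamino in place of hydrogen on an aromatic carbon), and in this assay compound 2 gives 1300 nM, so that a 2.6-fold higher number from compound 1 to compound 2 (0.41 log units; beyond the scatter). Compound 3 `Nc1ccc(C(=O)/C=C/c2ccccc2)cc1` shares the skeleton of compound 1 but differs at the ring nitrogen, (hydrogen in place of (1-bromoethenyl)carbonyl on a nitrogen on an aromatic ring); in this assay compound 3 gives 7900 nM, and a 16-fold higher number from compound 1 to compound 3 (1.20 log units; beyond the scatter), which leaves compound 3 with the highest number of the three.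

Compound 4 `CN(C)c1ccc(/C=C/C(=O)c2ccc(N)cc2)cc1` has not yet been measured. It stands to compound 3 as compound 2 stands to compound 1: dimethylamino in place of hydrogen on an aromatic carbon. The place of the change is described in identical terms in both pairs, so the change is the same one, made on a different core; the two cores differ in the way already given for compound 1 and compound 3. For compound 4 in this assay the expected step is a 2.5-fold higher number from compound 3 to compound 4 (0.40 log units; beyond the scatter), because a 2.6-fold higher number from compound 1 to compound 2 (0.41 log units; beyond the scatter) was seen for the same change. Compound 4 is therefore estimated at 20000 nM, with a range from 8000 nM to 50000 nM.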

Compound 4, half-maximal inhibitory concentration: 9900 nM
Compound 4: the middle estimate sits 2.0-fold (0.31 log units) above what was measured, and the stated range covers the measured number.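

In this assay, dimethylamino in place of hydrogen on an aromatic carbon gives a 1.3-fold higher number from compound 3 to compound 4 (0.10 log units; within the scatter), and set beside the same change on the core of compound 1, the two steps do not differ measurably: the same change on two cores in this assay, a 2.6-fold higher number (0.41 log units; beyond the scatter) from compound 1 to compound 2 and a 1.3-fold higher number (0.10 log units; within the scatter) from compound 3 to compound 4, 2.1-fold (0.32 log units) apart, within the scatter of two such steps. The other change, hydrogen in place of (1-bromoethenyl)carbonyl on a nitrogen on an aromatic ring, gives a 7.6-fold higher number from compound 2 to compound 4 (0.88 log units; beyond the scatter), and it too reads alike in both settings: the same change on two cores in this assay, a 16-fold higher number (1.20 log units; beyond the scatter) from compound 1 to compound 3 and a 7.6-fold higher number (0.88 log units; beyond the scatter) from compound 2 to compound 4, 2.1-fold (0.32 log units) apart, within the scatter of two such steps. This shows that, for these four compounds, both changes carried from one core to the other without a detectable difference in step size, but it does not show that the steps are identical, since the scatter of two such steps could hide a real gap, and it rests on one pair of cores only.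

The compounds shown leave open whether a methoxy group or a chlorine atom in place of dimethylamino would carry over in the same way. They also leave open how a plain acetyl group or an unbrominated acryloyl group on the ring nitrogen would compare with (1-bromoethenyl)carbonyl.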